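This account rests on a few compounds, and the source may have more. Where it says the series, first, only, none or still open, it means among the compounds named here.

Compound 1 `Nc1nc(N)c(CCCNc2cc(F)ccc2[N+](=O)[O-])c(O)n1`: > 100000 nM
Compound 2 `COC(=O)c1ccc(CN(CCCc2c(N)nc(N)nc2O)c2cc(F)c([N+](=O)[O-])cc2[N+](=O)[O-])cc1`: 3500 nM

Among the compounds with values here, in a functional assay on CCRF-CEM cells (Homo sapiens) for cytotoxicity, in the presence of a further agent that is not named here (on this read-out higher numbers stand for weaker inhibition and lower numbers for stronger inhibition), compound 2 gives 3500 nM, the only exact number so far. For compound 1, > 100000 nM is a limit of the assay and not an exact number. Compound 3 `Nc1nc(N)c(CCCNc2cc(F)c([N+](=O)[O-])cc2[N+](=O)[O-])c(O)n1` differs from compound 2 by hydrogen in place of 4-(methoxycarbonyl)benzyl on a nitrogen on an aromatic ring. Compound 1 also has no such benzyl group, and its result is the limit of > 100000 nM. In this assay, a large step towards weaker inhibition is therefore expected, estimated as an 8.6-fold higher number from compound 2 to compound 3 (0.93 log units; beyond the scatter). Compound 3 is estimated at 30000 nM, with an expected range of 6000 nM to 100000 nM.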

Compound 3, half-maximal inhibitory concentration: 1200 nM
Beside the measured number, compound 3's estimate is 25-fold (1.40 log units) above it; the whole stated range lies above it.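

On the nitrogen on an aromatic ring, the 4-(methoxycarbonyl)benzyl group turns out not to be needed for activity in this assay: hydrogen in its place gives a 2.9-fold lower number from compound 2 to compound 3 (0.46 log units; beyond the scatter). Compound 3 lacks this group just as compound 1 does, so the much larger difference between them goes with the other change, nitro in place of hydrogen on an aromatic carbon, which gives an at least 83-fold lower number from compound 1 to compound 3 (1.92 log units; beyond the scatter). The result for compound 1 is a limit of the assay and not an exact number: the limit of > 100000 nM in this assay, at which 1 of the 3 values shown sits.

As far as these compounds go, how a methyl group or a plain benzyl group on that nitrogen would compare remains open. So does the effect of a carboxylic acid in place of the methyl ester.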